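Swapping the acid group on a quinoline-type inhibitor

The compounds below may be only part of what the source reports. "The series", "measured", "known", "first", "only" and "open" are said of these compounds alone.

Measured so far:
- compound 1 `O=C(O)c1cnc2cc(F)ccc2c1O`: 11000000 nM
- compound 2 `O=C(O)c1cnc2cc(S(=O)(=O)O)ccc2c1O`: 3090000 nM

Both values come from an assay on isolated protein with malate dehydrogenase, cytoplasmic (Sus scrofa) as the target; on this read-out lower numbers stand for stronger inhibition and higher numbers for weaker inhibition. Among the compounds with values here, compound 2 holds the lowest of the two numbers, and its only neighbour is compound 1, which gave a 3.6-fold lower number from compound 1 to compound 2 (0.55 log units; beyond the scatter). Compound 3 `O=C(O)c1ccc2c(O)c(C(=O)O)cnc2c1` keeps the shared core of compound 2 and changes one group: carboxy in place of sulfo on an aromatic carbon. Within the data shown here, no measured pair compares carboxy with sulfo directly. Among the measured compounds shown here, the one step available, from fluoro to sulfo, was modest in size, so a change between two groups of this kind is expected to be small. The number for compound 3 in this assay is expected to land near that of compound 2, perhaps slightly lower, a step of a 1.5-fold lower number from compound 2 to compound 3 (0.19 log units; within the scatter). The estimate for compound 3 is 2000000 nM, with a range from 500000 nM to 8000000 nM.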

Compound 3, half-maximal inhibitory concentration: 1290000 nM
Compound 3: middle estimate off by 1.6-fold (0.19 log units), on the high side; low and high end bracket the measured number.
By their numbers in this assay, from the lowest: compound 3; then compound 2; then compound 1.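

In this assay, the position now has a direct comparison between sulfo and carboxy, and carboxy in place of sulfo gives a 2.4-fold lower number from compound 2 to compound 3 (0.38 log units; beyond the scatter). Carboxy in place of fluoro on the same aromatic carbon gives an 8.5-fold lower number from compound 1 to compound 3 (0.93 log units; beyond the scatter), the largest step among the three compounds, so the lower number of compound 2 does not depend on sulfo itself. Nothing shown explains why the three groups fall in this order.

The compounds shown leave open how an amine or a methyl ester would rank at this position, and therefore whether carboxy is uniquely favoured or simply one of several suitable groups. They also leave open whether carboxy would give a similar step on a different carbon of the shared core.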